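Swapping the amide aryl group: compound 2 to compound 3

A few compounds are considered here, and "the series" means these few. Any claim that something is new, unique, unknown or untested is made for them only; others in the source may bear on it.

- compound 1 `C[C@@]1(c2cc(NC(=O)c3ncc(C#N)cc3Cl)ccc2F)C=C(CF)OC(N)=N1` at 57%
- compound 2 `Cc1cc(C#N)cnc1C(=O)Nc1ccc(F)c([C@]2(C)C=C(CF)OC(N)=N2)c1` at 63%

Within the data shown here, both values come from an ADME assay on microsomes from liver (Homo sapiens) for metabolic stability, read by LC-MS, using NADPH, with a stated time of 30 min, tested at 0.1 uM (on this read-out higher numbers stand for a more stable compound and lower numbers for a less stable compound), and lie within the scatter of each other, so compound 2 stands level with compound 1 on the numbers so far. Among the measured compounds shown here, the one measured step (a number 6 percentage points higher from compound 1 to compound 2 (within the scatter)) is methyl in place of chloro on an aromatic carbon.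

Compound 3 `COc1cnc(C(=O)Nc2ccc(F)c([C@]3(C)C=C(CF)OC(N)=N3)c2)cn1` carries 5-methoxypyrazin-2-yl in place of 5-cyano-3-methylpyridin-2-yl on a carbonyl carbon. The measured step bears on this change only weakly, since it exchanges a single substituent while here the whole group is replaced. For the measured compounds named here, no measured step covers such a replacement, and the series offers no firm direction for it. The expected change in this assay is small and uncertain (a number 5 percentage points lower from compound 2 to compound 3 (within the scatter)), with no shift beyond the scatter confidently foreseen. Compound 3 is estimated at 58% with an expected range from 38% to 76% as the likely span.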

Compound 3, percent of the compound remaining: 80%
Estimate against measurement, compound 3: 22 percentage points below; the measured number lies above the stated range.
By their numbers in this assay, from the lowest: compounds 1 and 2 (each within the scatter of the next); then compound 3.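

In this assay, exchanging the whole aryl group on the carbonyl carbon moves the number beyond the scatter, which the single-substituent exchange, a number 6 percentage points higher from compound 1 to compound 2 (within the scatter), did not do. 5-Methoxypyrazin-2-yl in place of 5-cyano-3-methylpyridin-2-yl gives a number 17 percentage points higher from compound 2 to compound 3 (beyond the scatter), and the same group in place of 3-chloro-5-cyanopyridin-2-yl gives a number 23 percentage points higher from compound 1 to compound 3 (beyond the scatter), so the rise appears from both starting points, and the read-out at this place responds more to the identity of the group as a whole than to methyl versus chloro among the compounds shown. No measurement here bears on why the number rises.

The change removes the nitrile and the methyl or chloro, and adds a methoxy and a second ring nitrogen all at once, so the compounds shown do not tell which of these carries the step. A methoxypyridinyl group on the same carbonyl carbon, or an amine or an ethoxy group in place of the methoxy on the pyrazine, would help separate these contributions and show how far the rise in this read-out extends.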